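The source may hold more compounds than are shown below. What is called first, only, known or untested is meant among the compounds shown, and "the series" means these compounds.

Measured so far:
- compound 1 `O=C1/C(=C/c2ccc3ccccc3c2)CNC/C1=C\c1ccc2ccccc2c1`: "not active" (no number reported)
- compound 2 `O=C1/C(=C/c2ccc(OCc3ccc(Br)cc3)cc2)CNC/C1=C\c1ccc(OCc2ccc(Br)cc2)cc1`: 49%
- compound 3 `Cc1ccsc1/C=C1\CNC/C(=C\c2sccc2C)C1=O`: 27%

Notes on the series. The read-out throughout is a functional assay on the whole organism (strain Fischer-344) with Rattus norvegicus as the target, read by paw edema, with a stated time of 3.5 h, at a dose of 0.01 mmol/kg by the intraperitoneal route; a lower number here means less inhibition, a higher number more inhibition at the dose given (going by the name of the read-out). In this assay compound 1 gives "not active" (no number reported), so there is no single number to place it on; it stands below the two compounds that do carry a number. In this assay compound 2 gives 49% and compound 3 gives 27%; these two differ from each other by more than the scatter, and both differ from compound 1 in the substituents on the shared core, so nothing about the ring nitrogen itself can be read from them.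

Compound 4 `C=CC(=O)N1C/C(=C\c2ccc3ccccc3c2)C(=O)/C(=C/c2ccc3ccccc3c2)C1` is the next compound to be tested in this assay. It differs from compound 1 in one place: vinylcarbonyl in place of hydrogen on an amine nitrogen in a ring

Among the compounds with values here, no pair of measured compounds differs by this change alone, so the size of the step cannot be taken from the data. With compound 1 reported as inactive, the expectation is a step upward of modest size at most, and a result again without a number remains a real possibility. The value expected for compound 4 in this assay is 20%, with a range from 0% to 50%.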

Compound 4, a percentage reported as inhibition, in the whole organism at one dose (the size of the read-out at that dose, not a potency): 27%
The estimate for compound 4 lay 7 percentage points below the measured number; measured number inside the range.
By their numbers in this assay, from the lowest: compounds 3 and 4 (each within the scatter of the next); then compound 2.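

In this assay compound 1 gives "not active" (no number reported) and compound 4 gives 27% and no step can be read between compound 1 and compound 4. The compounds shown leave open what size of change vinylcarbonyl in place of hydrogen on an amine nitrogen in a ring brings. No measured evidence bears on this result.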